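Furan-2-yl in place of pyridin-3-yl on the shared core

A few compounds are considered here, and "the series" means these few. Any claim that something is new, unique, unknown or untested is made for them only; others in the source may bear on it.

In a functional assay on T47D cells (Homo sapiens) for cytotoxicity, read by CCK-8 assay and cell counting, with a stated time of 2 days (on this read-out higher numbers stand for weaker inhibition and lower numbers for stronger inhibition), compound 2 `Oc1ccc(-c2cc(-c3cccnc3)nc(-c3cccc(Cl)c3)c2)cc1` gives 25700 nM, the higher of the two numbers measured; compound 1 `Oc1ccc(-c2cc(-c3ccco3)nc(-c3ccccc3Cl)c2)cc1` gives 5480 nM in this assay, a gap beyond the usual scatter. Compound 3 `Oc1ccc(-c2cc(-c3cccc(Cl)c3)nc(-c3ccco3)c2)cc1` has not been measured. It differs from compound 2 by furan-2-yl in place of pyridin-3-yl on an aromatic carbon. Compound 1 also carries furan-2-yl and gives the lower number, so compound 3 is expected to move toward it, with a step of a 2.9-fold lower number from compound 2 to compound 3 (0.46 log units; beyond the scatter) in this assay. Compound 3 is estimated at 9000 nM, within a range of 3000 nM to 30000 nM.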

Compound 3, half-maximal inhibitory concentration: 5220 nM
For compound 3 the middle estimate is 1.7-fold (0.24 log units) above the measured one, within the range that was stated.
By their numbers in this assay, from the lowest: compounds 3 and 1 (each within the scatter of the next); then compound 2.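

In this assay furan-2-yl in place of pyridin-3-yl gives a 4.9-fold lower number from compound 2 to compound 3 (0.69 log units; beyond the scatter) with nothing else altered, a reading that compounds 1 and 2, which differ in two places, could not give. With furan-2-yl held fixed, 3-chlorophenyl in place of 2-chlorophenyl gives a 1.0-fold lower number from compound 1 to compound 3 (0.02 log units; within the scatter) and so stays within the scatter, which means the place of the chlorine shows no clear effect here.

On these data alone, whether an amine or a carboxylic acid on this aromatic carbon would read differently stays open. No evidence on the reason for these steps is available.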